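Swapping phenoxy for chloro in a cytotoxic series

The source may report more compounds than this note shows. Statements on the series, on what has been measured and on what is new or still open speak of the compounds shown alone.

Three compounds have so far been measured in a functional assay on KB cells (Homo sapiens) for cytotoxicity, read by MTT assay, with a stated time of 72 h; on this read-out higher numbers stand for an effect only at larger amounts of compound and lower numbers for an effect already at smaller amounts:

Compound 1 `COc1ccc(/C=C2\C(=O)N(c3c(Cl)cccc3Cl)c3ccccc32)cc1OC` gives 10 ug/mL.
Compound 2 `O=C1/C(=C\c2cc3ccccc3nc2Cl)c2ccccc2N1c1c(Cl)cccc1Cl` gives 10 ug/mL.
Compound 3 `O=C1/C(=C\c2cccc(Oc3ccccc3)c2)c2ccccc2N1c1c(Cl)cccc1Cl` gives 5 ug/mL.

All three share the same core and differ only in the aryl group attached to it. Compound 3 carries the lowest number of the three in this assay, but the two others sit within the usual scatter of it, so the three compounds cannot be told apart with confidence; they behave, on these numbers, as one group.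

Compound 4 `O=C1/C(=C\c2cccc(Cl)c2)c2ccccc2N1c1c(Cl)cccc1Cl` is the next compound to be tested. Compared with compound 3 the change is: chloro in place of phenoxy on an aromatic carbon. For the measured compounds named here, no pair of measured compounds is separated by exactly this change, so the data give no direct guide to how large its effect on the read-out will be.

Since the three measured compounds, with three different aryl groups, all fall into a narrow window in this assay, the expectation is that the step from compound 3 to compound 4 will stay within the scatter, which is a 1.6-fold higher number from compound 3 to compound 4 (0.20 log units; within the scatter). On that basis compound 4 is estimated at 8 ug/mL, with a likely range from 3 ug/mL to 20 ug/mL.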

Compound 4, concentration for half-maximal effect: 2 ug/mL
For compound 4 the middle estimate is 4.0-fold (0.60 log units) above the measured one; the measured number lies below the stated range.
By their numbers in this assay, from the lowest: compound 4; then compounds 3, 1 and 2 (each within the scatter of the next).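

Chloro in place of phenoxy on this aromatic carbon gives a 2.5-fold lower number from compound 3 to compound 4 (0.40 log units; beyond the scatter) in this assay and, unlike the differences among the earlier compounds, this step lies beyond the usual scatter. It shows that the read-out responds to what sits at this position, meta to a large group, which the first three compounds could not show: they differ from one another in more than one place, and their numbers stay within the scatter. Here, losing the whole phenoxy group with its aromatic ring and keeping only a single chlorine goes with an effect at smaller amounts of compound, although nothing available explains why this happens.

On these data alone, this is one pair, so it remains open whether the shift follows the smaller number of heavy atoms or belongs to chloro itself. Compounds carrying fluoro, an amine or a carboxylic acid on the same aromatic carbon, with the rest of compound 4 unchanged, would help separate these two readings and show how far the trend extends.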